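The compounds below may be only part of what the source reports. "The series", "measured", "known", "first", "only" and "open" are said of these compounds alone.

In a functional assay on P388 cells (Mus musculus) for cytotoxicity (a higher number here means a weaker inhibitor, a lower number a stronger inhibitor), compound 1 `COc1ccc2cc1Oc1ccc(cc1)C[C@H]1C(=O)N(C)[C@@H](C2)C(=O)N[C@H](C)C(=O)N[C@@H](C)C(=O)N(C)[C@@H](Cc2ccccc2)C(=O)N[C@@H](C)C(=O)N1C` gives 295 nM and compound 2 `COc1ccc2cc1Oc1ccc(cc1)C[C@H]1C(=O)N(C)[C@@H](C2)C(=O)N[C@H](C)C(=O)N[C@@H](C)C(=O)N(C)[C@@H](Cc2ccc(C)cc2)C(=O)N[C@@H](C)C(=O)N1C` gives 24 nM as the lower of the two numbers. Compound 3 `C=Cc1ccc(C[C@H]2C(=O)N[C@@H](C)C(=O)N(C)[C@H]3Cc4ccc(cc4)Oc4cc(ccc4OC)C[C@@H](C(=O)N[C@H](C)C(=O)N[C@@H](C)C(=O)N2C)N(C)C3=O)cc1` differs from compound 2 by vinyl in place of methyl on an aromatic carbon as vinyl in place of methyl on an aromatic carbon. Among the compounds with values here, the only measured step of a 12-fold lower number from compound 1 to compound 2 (1.09 log units; beyond the scatter) was large and concerned methyl in place of hydrogen on an aromatic carbon. It does not compare vinyl with methyl, so no step beyond the scatter is expected in this assay in either direction. The expected step is a 1.3-fold higher number from compound 2 to compound 3 (0.10 log units; within the scatter) on this estimate. For compound 3 the estimated value is 30 nM with an expected range from 10 nM to 90 nM on measurement.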

Compound 3, half-maximal inhibitory concentration: 17 nM
Beside the measured number, compound 3's estimate is 1.8-fold (0.25 log units) above it; measured number inside the range.
By their numbers in this assay, from the lowest: compounds 3 and 2 (each within the scatter of the next); then compound 1.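

In this assay, the step of a 1.4-fold lower number from compound 2 to compound 3 (0.15 log units; within the scatter) stays within the scatter, so methyl and vinyl on this aromatic carbon cannot be told apart. The step of a 17-fold lower number from compound 1 to compound 3 (1.24 log units; beyond the scatter) lies beyond the scatter, so the drop from the unsubstituted ring is not unique to methyl: both carbon groups at this position share it. Nothing measured here accounts for this result.

Open, going by these compounds, is whether a longer chain, such as butyl, would keep the number in this range. Also open, on these data alone, is what an amine or a carboxylic acid at this position would give.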